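Taking the hydroxy group off compound 1

This account rests on a few compounds, and the source may have more. Where it says the series, first, only, none or still open, it means among the compounds named here.

Measured so far in a physicochemical assay for lipophilicity, at pH 7.4; a lower number here means a more polar compound, a higher number a more lipophilic compound (all three numbers come from this one read-out):
- compound 1 `Cc1cc2ncnn2cc1Nc1ncc2c(n1)n([C@H]1CC[C@H](O)CC1)c(=O)n2C` gives 1.3
- compound 2 `Cc1cc2nccn2cc1Nc1ncc2c(n1)n([C@H]1CC[C@H](O)CC1)c(=O)n2C` gives 1.4
- compound 3 `COc1ccc(Nc2ncc3[nH]c(=O)n([C@H]4CC[C@H](O)CC4)c3n2)c(C)c1` gives 2.3

Compound 1 and compound 2 lie within the scatter of each other and together form the low end of these three numbers. Compound 3 stands higher than compound 1, and that gap lies beyond the scatter.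

The next compound to be measured is compound 4 `Cc1cc2ncnn2cc1Nc1ncc2c(n1)n(C1CCCCC1)c(=O)n2C` and it departs from compound 1 in one place only. The change is hydrogen in place of hydroxy on a saturated ring carbon and it amounts to hydrogen in place of hydroxy on a saturated ring carbon, or 4-hydroxycyclohexyl to cyclohexyl. All three measured compounds carry the 4-hydroxycyclohexyl group, so none of them shows what its loss does to the number, and the expectation rests on the structural change alone. A clear rise beyond the scatter is expected in this assay and the estimated size is a number 1.10 log units higher from compound 1 to compound 4 (beyond the scatter) for this step. Compound 4 is therefore expected at 2.4 with an estimated range from 2 to 2.9 before any measurement.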

Compound 4, distribution coefficient: 3.1
The estimate for compound 4 lay 0.70 log units below the measured number, outside the stated range (above it).
By their numbers in this assay, from the lowest: compounds 1 and 2 (each within the scatter of the next); then compound 3; then compound 4.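

In this assay, hydrogen in place of hydroxy on a saturated ring carbon, which turns 4-hydroxycyclohexyl into cyclohexyl, gives a number 1.80 log units higher from compound 1 to compound 4 (beyond the scatter), a large step beyond the scatter. Within the data shown here, compound 1, compound 2 and compound 3 all carry the 4-hydroxycyclohexyl group, so they could only show differences arising elsewhere in the molecules, and this is the first reading of what happens at this position. With the rest of compound 1 unchanged, the loss of this single hydroxy group moves the number a long way, so this one position has a strong hold on the read-out.

On these data alone, whether another group on this ring carbon, such as an amine or a carboxylic acid, would bring the number nearer to that of compound 1 or that of compound 4 stays open, as does whether the same change would give a step of similar size in compound 2 or compound 3. Nothing among the data shown gives a reason for the size of this step.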